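Selenium-linked quinoline esters: aryl to benzyl on selenium

The compounds below may be only part of what the source reports. "The series", "measured", "known", "first", "only" and "open" are said of these compounds alone.

Three measured members of the series, compound 1 `CCOC(=O)c1cc([Se]c2ccccc2C)c2cc(OC)ccc2n1`, compound 2 `CCOC(=O)c1cc([Se]c2ccccc2)c2cc(Br)ccc2n1` and compound 3 `COc1ccc2nc(-c3c(Cl)cccc3Cl)cc([Se]c3ccccc3)c2c1`, were run in a functional assay on Jurkat cells (Homo sapiens) for cytotoxicity, read by MTT assay, with a stated time of 24 h; a lower number here means that less compound is needed, a higher number that more compound is needed for the effect. Compound 1 gives 14900 nM, the lowest number of the three, while compound 3 at 17000 nM and compound 2 at 20800 nM both lie within the usual scatter of it, so the three cannot be separated on these data.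

Compound 4 `CCOC(=O)c1cc([Se]Cc2ccccc2)c2cc(OC)ccc2n1` has not been measured. It differs from compound 1 in one place: benzyl in place of 2-methylphenyl on a selenium. Among the measured compounds shown here, no comparable single change between two measured compounds exists, so there is no step to lean on; the only guide is that the three measured numbers sit close together despite differing substituents on the selenium and on the shared core.

On that basis, no step beyond the scatter is expected in this assay from compound 1 to compound 4, in either direction, and the expected step is a 1.1-fold higher number from compound 1 to compound 4 (0.06 log units; within the scatter). For compound 4 the estimated value in this assay is 17000 nM, with a range from 8000 nM to 36000 nM.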

Compound 4, half-maximal effective concentration: 20800 nM
For compound 4 the middle estimate is 1.2-fold (0.09 log units) below the measured one; measured number inside the range.
By their numbers in this assay, from the lowest: compounds 1, 3, 2 and 4 (each within the scatter of the next).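

Among the compounds shown here, this is the first change that can be read at a single place: on a selenium whose other neighbours are aromatic carbon, benzyl in place of 2-methylphenyl gives a 1.4-fold higher number from compound 1 to compound 4 (0.14 log units; within the scatter) in this assay. The two groups match in the counts computed for them and differ in how the same atoms are joined, and that rearrangement leaves the number within the scatter. No measurement bears on a cause for this result.

As far as these compounds go, whether the selenium position stays equally insensitive to a different kind of group, such as an aminoethyl or a longer alkyl chain, remains open. Also open, from the compounds shown here alone, is whether the same change gives a similar step on a core carrying another substituent, since this single pair rests on the core of compound 1 alone.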